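Replacing the imidazolylmethyl arm of compound 1

The compounds below may be only part of what the source reports. "The series", "measured", "known", "first", "only" and "open" are said of these compounds alone.

Compound 1 `CC(C)C(Cc1ncc[nH]1)c1ccc(-c2ccc3cccc(F)c3c2)[nH]c1=O` gives 11 nM; compound 2 `CCn1ncc2c(F)cc(-c3ccc(C(CC)(CC)c4nnc(C)[nH]4)c(=O)[nH]3)cc21` gives 34 nM; compound 3 `CCn1ncc2c(F)cc(-c3ccc(C(CC)(CC)c4nncn4C)c(=O)[nH]3)cc21` gives 54 nM.

In an assay on CHO cells for displacement of a labelled ligand from prostaglandin E2 receptor EP3 subtype (Homo sapiens), read by radioligand binding (a higher number here means a weaker inhibitor, a lower number a stronger inhibitor), compound 1 has the lowest number of the three measured compounds. For the measured compounds named here, the only measured one-place step, a 1.6-fold higher number from compound 2 to compound 3 (0.20 log units; within the scatter), concerns a triazole on the core shared by compound 2 and compound 3 and does not touch the change studied here. Compound 4 `CC(C)C(c1ccc(-c2ccc3cccc(F)c3c2)[nH]c1=O)N1CCN/C1=N\C#N` differs from compound 1 by a group of 8 heavy atoms (4 carbon, 4 nitrogen; one five-membered non-aromatic ring with 2 hetero atoms) in place of a group of 6 heavy atoms (4 carbon, 2 nitrogen; one five-membered aromatic ring with 2 hetero atoms), on a saturated chain carbon bound to an aromatic carbon and a saturated chain carbon. Going by the values given here, no measured step bears on this change, so its direction and size are open. Compound 4 is therefore expected to lie near compound 1 with a wide margin, and the expected step is a 3.6-fold higher number from compound 1 to compound 4 (0.56 log units; beyond the scatter). The estimate for compound 4 is 40 nM, ranging from 8 nM to 250 nM.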

Compound 4, inhibition constant: 23 nM
Beside the measured number, compound 4's estimate is 1.7-fold (0.24 log units) above it; the range from low to high includes it.
By their numbers in this assay, from the lowest: compound 1; then compounds 4, 2 and 3 (each within the scatter of the next, the first and the last beyond it).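

In this assay, for the compounds shown here, this is the first measured change at the saturated chain carbon, and it gives a 2.1-fold higher number from compound 1 to compound 4 (0.32 log units; beyond the scatter). A modest step of this kind shows that a five-membered aromatic ring is not required at this place, since the non-aromatic ring group bearing a nitrile keeps the number low. Nothing measured here accounts for the step.

As far as these compounds go, whether the nitrile matters remains open, and the same ring bearing a carbonyl in its place would address that. From the compounds shown here alone, how an amine or a carboxylic acid would fare at this carbon is also open.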